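Hydroxy in Place of Trifluoromethyl: From Compound 3 to Compound 4

The source may hold more compounds than are shown below. What is called first, only, known or untested is meant among the compounds shown, and "the series" means these compounds.

Of the compounds shown here, three built on one shared core have been tested in a functional assay on the whole organism for inhibition, with Rattus norvegicus as the target, read by paw edema, with stated times of 30 min and 3 h, at a dose of 0.28 mmol/kg by the oral route; a higher number here means more inhibition at the dose given (going by the name of the read-out), a lower number less inhibition. Compound 1, `CCNC(=O)c1nc(-c2cc(OC)c(OC)c(OC)c2)n(-c2ccc(OC)cc2)n1`, gives 88%. Compound 2, `COc1ccc(-n2nc(C(=O)Nc3ccccc3C)nc2-c2cc(OC)c(OC)c(OC)c2)cc1`, gives 64% in this assay. Compound 3, `COc1ccc(-n2nc(C(=O)Nc3ccc(C(F)(F)F)cc3)nc2-c2cc(OC)c(OC)c(OC)c2)cc1`, gives 83% in this assay, the second highest of the three numbers: it sits within the scatter of compound 1 and beyond the scatter above compound 2. Replacing ethyl with 4-(trifluoromethyl)phenyl on the amide-type nitrogen is a number 5 percentage points lower from compound 1 to compound 3 (within the scatter), while a number 24 percentage points lower from compound 1 to compound 2 (beyond the scatter) and a number 19 percentage points higher from compound 2 to compound 3 (beyond the scatter) show that what sits on that ring can move the number by a modest amount.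

Compound 4, `COc1ccc(-n2nc(C(=O)Nc3ccc(O)cc3)nc2-c2cc(OC)c(OC)c(OC)c2)cc1`, differs from compound 3 in one place: hydroxy in place of trifluoromethyl on an aromatic carbon. Going by the values given here, no measured pair makes a change of this kind on that ring, so the only guidance comes from a number 19 percentage points higher from compound 2 to compound 3 (beyond the scatter) and a number 5 percentage points lower from compound 1 to compound 3 (within the scatter), which together bracket the effect of this ring's substituent between none and modest. A small fall or no step beyond the scatter is therefore expected, namely a number 7 percentage points lower from compound 3 to compound 4 (within the scatter). Compound 4 is estimated to give 76% in this assay, with a likely range from 58% to 90%.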

Compound 4, a percentage reported as inhibition, in the whole organism at one dose (the size of the read-out at that dose, not a potency): 64%
For compound 4 the middle estimate is 12 percentage points above the measured one; measured number inside the range.
By their numbers in this assay, from the lowest: compounds 2 and 4 (each within the scatter of the next); then compounds 3 and 1 (each within the scatter of the next).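

In this assay, going by these compounds alone, the swap of trifluoromethyl for hydroxy gives a number 19 percentage points lower from compound 3 to compound 4 (beyond the scatter), the first evidence that changing only the group on this aromatic carbon, para to a large group, with the rest of the molecule held constant, can shift the number by a modest amount. An aromatic ring on the amide-type nitrogen does not fix the outcome: a number 5 percentage points lower from compound 1 to compound 3 (within the scatter), yet a number 24 percentage points lower from compound 1 to compound 4 (beyond the scatter), while no change at the digits printed from compound 2 to compound 4 (within the scatter), so the 4-hydroxyphenyl and 2-methylphenyl groups cannot be told apart at this dose. Nothing available explains the fall seen with hydroxy at this place.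

The compounds shown cannot separate the loss of trifluoromethyl from the arrival of hydroxy, and a plain hydrogen, a chlorine, an amine or a carboxylic acid at the same place would help to show which of the two matters. On these data alone, each number also comes from a single dose, so it remains open whether these differences would hold at other doses.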